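Acyl chain extension on the anilide arm of aryl sulfonates

The source may report more compounds than this note shows. Statements on the series, on what has been measured and on what is new or still open speak of the compounds shown alone.

Measured compounds in a functional assay on HT-29 cells (Homo sapiens) for antiproliferative activity, read by sulforhodamine B assay, with a stated time of 48 h; on this read-out lower numbers stand for stronger inhibition and higher numbers for weaker inhibition:
compound 1 `CC(C)C(=O)Nc1cccc(S(=O)(=O)Oc2ccccc2C(C)C)c1`, 16000 nM
compound 2 `CC(=O)Nc1ccc(S(=O)(=O)Oc2ccccc2C(C)C)cc1`, 23000 nM
compound 3 `CC(=O)Nc1ccc(S(=O)(=O)Oc2ccccc2I)cc1`, 23000 nM

Compound 3 sits level with compound 2, and compound 1 lies within the scatter of both, so the three values cannot be ordered. Going by the values given here, the one single-point step, no change at the digits printed from compound 2 to compound 3 (within the scatter), concerns the substituent on the phenolic ring and leaves the number unchanged.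

Compound 4 `CCC(=O)Nc1ccc(S(=O)(=O)Oc2ccccc2I)cc1` carries methyl in place of hydrogen on a saturated chain carbon bound to a carbonyl carbon. Among the compounds with values here, no measured step varies this acyl chain, so nothing points to a shift, and any effect of the added carbon is unknown. In this assay compound 4 is therefore expected to show no change at the digits printed from compound 3 to compound 4 (within the scatter), an estimated 23000 nM with a range of 10000 nM to 50000 nM.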

Compound 4, half-maximal inhibitory concentration: 11000 nM
Beside the measured number, compound 4's estimate is 2.1-fold (0.32 log units) above it; the measured number falls inside the stated range.
By their numbers in this assay, from the lowest: compounds 4, 1, 2 and 3 (each within the scatter of the next, the first and the last beyond it).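

In this assay, acetamido to propanoylamino gives a 2.1-fold lower number from compound 3 to compound 4 (0.32 log units; beyond the scatter), the only step shown that lies beyond the scatter and the only one that varies the acyl chain. A single added methyl on this saturated chain carbon bound to a carbonyl carbon therefore registers, modestly, whereas iodo in place of isopropyl on the aromatic carbon did not. Nothing measured here accounts for the shift.

Going by these compounds, whether a longer chain such as butanoyl extends the shift remains open, as does the effect of an amine or a carboxylic acid at the chain end. Also open, on these data alone, is whether the same methyl gives a similar step on compound 2.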